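Switching the tetrazole attachment point in compound 1

The source may hold more compounds than are shown below. What is called first, only, known or untested is meant among the compounds shown, and "the series" means these compounds.

Compound 1 `CCCCCCCCc1ccc(OCC(=O)Cn2nnc(SC)n2)cc1` holds the lowest of the three numbers recorded in an assay on microsomes from brain for inhibition of Fatty-acid amide hydrolase 1 (Rattus norvegicus), read by fluorescence and HPLC, with a stated time of 60 min (on this read-out higher numbers stand for weaker inhibition and lower numbers for stronger inhibition), where compound 1 gives 31 nM. Compound 2 `CCCCCCCCc1ccc(OCC(=O)Cn2nnc(-c3ccccc3Cl)n2)cc1` gives 32 nM in this assay, and the step of a 1.0-fold higher number from compound 1 to compound 2 (0.01 log units; within the scatter) lies within the scatter, so the two cannot be ordered. Compound 3 `CCCCCCCCc1ccc(OCC(=O)Cn2nnc(-c3cccc(S(=O)(=O)N(C)C)c3)n2)cc1` gives 420 nM in this assay, and the step of a 14-fold higher number from compound 1 to compound 3 (1.13 log units; beyond the scatter) is large, as is a 13-fold higher number from compound 2 to compound 3 (1.12 log units; beyond the scatter).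

Compound 4 `CCCCCCCCc1ccc(OCC(=O)Cn2nnnc2SC)cc1` differs from compound 1 by 5-(methylsulfanyl)-1H-tetrazol-1-yl in place of 5-(methylsulfanyl)-2H-tetrazol-2-yl on a saturated chain carbon bound to a carbonyl carbon. Within the data shown here, none of the measured steps bears on this change: all three concern the group on the aromatic carbon of the shared core, not the point at which the ring joins the saturated chain carbon bound to the carbonyl carbon. The measured data therefore offer no direct guide, and the expectation rests on the unchanged remainder of compound 1.

Compound 4 is expected to give a number near that of compound 1, with a possible modest rise, so the estimated step is a 1.9-fold higher number from compound 1 to compound 4 (0.29 log units; within the scatter). The estimate for compound 4 in this assay is 60 nM, with a range from 15 nM to 300 nM.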

Compound 4, half-maximal inhibitory concentration: 22 nM
The estimate for compound 4 lay 2.7-fold (0.44 log units) above the measured number; measured number inside the range.
By their numbers in this assay, from the lowest: compounds 4, 1 and 2 (each within the scatter of the next); then compound 3.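

In this assay, exchanging 5-(methylsulfanyl)-2H-tetrazol-2-yl for 5-(methylsulfanyl)-1H-tetrazol-1-yl on a saturated chain carbon bound to a carbonyl carbon gives a step that stays within the scatter (a 1.4-fold lower number from compound 1 to compound 4 (0.15 log units; within the scatter)), so the two compounds cannot be ordered. Among these compounds, the earlier steps all changed the group on the aromatic carbon, so this is the first reading at this place, and it shows that joining the same atoms differently leaves the number of this methylsulfanyl pair unresolved. Nothing measured here accounts for this result.

Whether the same holds with 2-chlorophenyl or 3-(dimethylsulfamoyl)phenyl on the ring remains open, since the compounds shown pair the two attachments only with methylsulfanyl. Also open, on these data alone, is how the number would respond to a carboxylic acid or an amine in place of the tetrazole on that chain carbon.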